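This account rests on a few compounds, and the source may have more. Where it says the series, first, only, none or still open, it means among the compounds named here.

Compound 1, `Cc1ccc2c(NCc3ccc(NC(=O)C4CCN(Cc5ccc(F)cc5)CC4)cc3)nc(N(C)C)nc2c1`, is assessed in a functional assay on SV5A8 cells (Homo sapiens) for cytotoxicity; a higher number here means a weaker inhibitor, a lower number a stronger inhibitor. In this assay compound 1 gives only > 4820 nM, which is a limit rather than a number. Compound 2, `Cc1ccc2c(NCc3ccc(NC(=O)C4CCN(Cc5ccccc5)CC4)cc3)nc(N3CCC(N4CCCC4)CC3)nc2c1`, likewise gives only a limit of > 8090 nM in this assay. Compound 3, `Cc1ccc2c(NCc3ccc(NC(=O)C4CCN(Cc5ccccc5)CC4)cc3)nc(N3CCCC3)nc2c1`, also gives only a limit of > 7790 nM in this assay. The step that the two limits leave unreadable from compound 2 to compound 3 is thus unreadable, as all three values sit at limits (the limit of > 4820 nM in this assay, at which 1 of the 3 values shown sits, (the limit of > 7790 nM in this assay, at which 1 of the 3 values shown sits), (the limit of > 8090 nM in this assay, at which 1 of the 3 values shown sits)). Compound 4, `Cc1ccc2c(NCc3ccc(NC(=O)C4CCN(CC(C)C)CC4)cc3)nc(N(C)C)nc2c1`, differs from compound 1 by isopropyl in place of 4-fluorophenyl on a saturated chain carbon bound to an amine nitrogen in a ring. For the measured compounds named here, no measured step bears on this change, and every value shown is a limit, so compound 4 is expected to sit at a limit again. The estimate for compound 4 in this assay is 10000 nM, within 3000 nM to 40000 nM. The step that the limit leaves unreadable from compound 1 to compound 4 is expected to lie within the scatter.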

Compound 4, half-maximal inhibitory concentration: > 10500 nM
Compound 4 ended at the assay's limit; the forecaster's own chance of this, stated with the estimate: 85%; middle value at least 1.0-fold (0.02 log units) away from the limit.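

In this assay compound 4 gives only a limit, > 10500 nM. For the compounds shown here, compound 1 also gives only a limit, > 4820 nM, so no step between these two compounds can be read. The compounds shown leave open whether isopropyl in place of 4-fluorophenyl changes cytotoxicity at all.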